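The compounds below may be only part of what the source reports. "The series", "measured", "known", "first", "only" and "open" are said of these compounds alone.

Measured compounds:
Compound 1, `COc1ccc(C2C(OC(C)=O)C(=O)N2c2cc(OC)c(OC)c(OC)c2)cn1`. In a functional assay on IMR-32 cells (Homo sapiens) for cytotoxicity (on this read-out higher numbers stand for weaker inhibition and lower numbers for stronger inhibition), compound 1 reaches only a limit of the assay, > 1000 nM.
Compound 2, `COc1ccc(C2C(O)C(=O)N2c2cc(OC)c(OC)c(OC)c2)cn1`. In this assay compound 2 likewise sits at a limit, > 1000 nM.
Compound 3, `COc1ccc2cc(C3C(OC(C)=O)C(=O)N3c3cc(OC)c(OC)c(OC)c3)ccc2c1`. In this assay compound 3 also gives a limit, > 1000 nM.

From compound 1 to compound 2 the change is hydrogen in place of acetyl on an oxygen on a saturated carbon. The step it made, a step that the two limits leave unreadable from compound 1 to compound 2, cannot be read in size because of the limit of > 1000 nM in this assay, at which 3 of the 3 values shown sit. Compound 4, `COc1ccc2cc(C3C(O)C(=O)N3c3cc(OC)c(OC)c(OC)c3)ccc2c1`, has not yet been measured. Going by the values given here, it differs from compound 3 by hydrogen in place of acetyl on an oxygen on a saturated carbon, the same change in the same place as the one from compound 1 to compound 2. How the core of compound 3 differs from the core of compound 1 is not broken down here.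

For compound 4 the earlier step offers no size to carry over, so the expectation rests on the limit at which compound 3 stands, > 1000 nM. Compound 4 is therefore expected to remain near or at that limit, with an expected step that the limit leaves unreadable from compound 3 to compound 4. The estimate for compound 4 is 3000 nM, within 1000 nM to 10000 nM.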

Compound 4, half-maximal inhibitory concentration: 89 nM
Compound 4: middle estimate off by 34-fold (1.53 log units), on the high side, outside the stated range (below it).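

On one of the two cores, the change from acetoxy to hydroxy in this assay gives an at least 11-fold lower number from compound 3 to compound 4 (1.05 log units; beyond the scatter), so this single change can carry a large step in this series. On the other core, the same change leaves compound 2 at a limit of the assay, > 1000 nM. The size of the step on that core cannot be read, so the series does not show whether the change acts alike on both cores or how far it carries from one to the other, because both ends of that step are limits: the limit of > 1000 nM in this assay, at which 3 of the 4 values shown sit.

Among the compounds shown, only acetyl and hydrogen stand on that oxygen, so it remains open how a methyl ether, a longer acyl chain such as propionyl, or an amine in place of the hydroxy would read in this assay. As far as these compounds go, it also remains open whether any such group would bring the core of compound 1 off its limit.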